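The compounds below may be only part of what the source reports. "The series", "measured", "known", "first", "only" and "open" are said of these compounds alone.

Compound 1 `Cc1ccccc1NC(=O)Nc1cc(C(C)(C)C)nn1-c1ccccc1`: 8.6 degrees C
Compound 2 `CCOc1ccc(NC(=O)Nc2cc(C(C)(C)C)nn2-c2ccccc2)cc1`: 0.8 degrees C
Compound 3 `Cn1nc(C(C)(C)C)cc1NC(=O)Nc1cc(C(F)(F)F)cc(C(F)(F)F)c1`: 1.1 degrees C

In an assay on isolated protein for inhibition of serine/threonine-protein kinase 10 (Homo sapiens), read by thermal shift assay, tested at 10 uM (on this read-out lower numbers stand for weaker stabilisation of the target and higher numbers for stronger stabilisation of the target against heat), compound 1 stands far above the other two, whereas compound 3 and compound 2 lie within the scatter of each other, so compound 3 sits among the weak stabilisers. Compound 4 `CC(C)(C)c1cc(NC(=O)Nc2cc(C(F)(F)F)cc(C(F)(F)F)c2)n(-c2ccc(Br)cc2)n1` differs from compound 3 by 4-bromophenyl in place of methyl on an aromatic nitrogen. Among the compounds with values here, the only measured step, a number 7.8 degrees C lower from compound 1 to compound 2 (beyond the scatter), concerns the group on an amide-type nitrogen, not the ring nitrogen, so no step bears directly on this change; it shows only that this series can swing widely. Compound 1 and compound 2, both bearing phenyl on that ring nitrogen, give no consistent signal. Compound 4 is therefore expected to give 2.5 degrees C, between 0 degrees C and 7 degrees C, an estimated step of a number 1.4 degrees C higher from compound 3 to compound 4 (beyond the scatter).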

Compound 4, shift of the target's melting temperature: -0.3 degrees C
Estimate against measurement, compound 4: 2.8 degrees C above; the measured number lies below the stated range.
By their numbers in this assay, from the lowest: compound 4; then compounds 2 and 3 (each within the scatter of the next); then compound 1.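

In this assay, 4-bromophenyl in place of methyl on the aromatic nitrogen gives a number 1.4 degrees C lower from compound 3 to compound 4 (beyond the scatter), the first step read at this position. A large aromatic group here therefore brings no gain in stabilisation while the rest of compound 3 stays fixed, and the step is small beside a number 7.8 degrees C lower from compound 1 to compound 2 (beyond the scatter). Nothing available explains this drop.

The compounds shown leave open whether this position behaves the same way when 2-methylphenyl sits on the amide-type nitrogen, as in compound 1. They also leave open how an amine or a carboxylic acid in place of the bromine would read.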